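A few compounds are considered here, and "the series" means these few. Any claim that something is new, unique, unknown or untested is made for them only; others in the source may bear on it.

Compound 3 `Nc1ccccc1NC(=O)c1ccc(CSC(=S)N2CCN(c3ccc(F)cc3)CC2)cc1` gives 20.9% in a functional assay on A-375 cells (Homo sapiens) for antiproliferative activity, read by CCK-8 assay, with a stated time of 72 h, tested at 2 uM (a higher number here means a stronger effect of the compound at the concentration tested, a lower number a weaker effect), the lowest of the three numbers shown. Compound 1 `Nc1ccccc1NC(=O)c1ccc(CSC(=S)N2CCN(c3ccc(Cl)cc3)CC2)cc1` gives 32.2% in this assay, and compound 2 `Nc1ccccc1NC(=O)c1ccc(CSC(=S)N2CCN(c3ccncc3)CC2)cc1` gives 85.7%. The step of a number 11.3 percentage points lower from compound 1 to compound 3 (beyond the scatter) is modest, while the step of a number 64.8 percentage points lower from compound 2 to compound 3 (beyond the scatter) is large. Compound 4 `Nc1ccccc1NC(=O)c1ccc(CSC(=S)N2CCN(c3ncccn3)CC2)cc1` differs from compound 3 at the ring nitrogen: pyrimidin-2-yl in place of 4-fluorophenyl on an amine nitrogen in a ring. Among the compounds with values here, two measured steps bear on this change. The step of a number 53.5 percentage points higher from compound 1 to compound 2 (beyond the scatter) shows that a six-membered aromatic ring with a nitrogen in place of a halogenated phenyl on the same ring nitrogen gave a large rise, and the step of a number 64.8 percentage points lower from compound 2 to compound 3 (beyond the scatter) shows the same in reverse. Pyrimidin-2-yl is not pyridin-4-yl, so the size carried over is uncertain, but a rise beyond the scatter is expected for compound 4, as a number 39.1 percentage points higher from compound 3 to compound 4 (beyond the scatter). Compound 4 is therefore estimated at 60% in this assay, in a range from 25% to 90%.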

Compound 4, a percentage reported as inhibition, at one concentration (the size of the read-out at that concentration, not a potency): 24%
Estimate against measurement, compound 4: 36 percentage points above; measured number outside the range, below it.
By their numbers in this assay, from the lowest: compounds 3, 4 and 1 (each within the scatter of the next, the first and the last beyond it); then compound 2.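

The steps of a number 3.1 percentage points higher from compound 3 to compound 4 (within the scatter) and a number 8.2 percentage points lower from compound 1 to compound 4 (within the scatter) place pyrimidin-2-yl on this amine nitrogen level with the 4-fluorophenyl and 4-chlorophenyl groups in this assay, so the rise seen with pyridin-4-yl does not carry over to this other six-membered aromatic ring with nitrogen. The step of a number 61.7 percentage points lower from compound 2 to compound 4 (beyond the scatter) shows that nitrogen in the aromatic ring at this place does not by itself give the high reading, and compound 4 goes against any such pattern, leaving compound 2 alone apart from the other three compounds.

On these data alone, what pyridin-3-yl, pyridin-2-yl or pyrimidin-5-yl would give on this amine nitrogen stays open, as does whether the reading of compound 2 is tied to pyridin-4-yl alone. As far as these compounds go, the reading of an unsubstituted phenyl at this place is also open. Nothing measured here accounts for the gap between the pyridin-4-yl and pyrimidin-2-yl groups.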